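A few compounds are considered here, and "the series" means these few. Any claim that something is new, unique, unknown or untested is made for them only; others in the source may bear on it.

Compound 2 `CCCCC(O)c1cccc(NC(=O)NC(=O)CCl)c1` and compound 1 `CCCCCc1cccc(NC(=O)NC(=O)CCl)c1` share a core and differ only by a hydroxy on the saturated chain carbon. In a functional assay on MCF7 cells (Homo sapiens) for antiproliferative activity, with a stated time of 48 h (a lower number here means a stronger inhibitor, a higher number a weaker inhibitor), compound 1 gives 8300 nM, and compound 2 gives 5700 nM, the lower of the two numbers, with a 1.5-fold lower number from compound 1 to compound 2 (0.16 log units; within the scatter). Compound 3 `CCCCC(O)c1cccc(NC(=O)CCCl)c1` carries 2-chloroethyl in place of ((chloromethyl)carbonyl)amino on a carbonyl carbon. Among the compounds with values here, no measured step touches this part of the molecule, so the single known step gives no guide for it. The number for compound 3 is therefore estimated with wide bounds: 15000 nM (range 4000 nM to 60000 nM), an expected 2.6-fold higher number from compound 2 to compound 3 (0.42 log units; beyond the scatter).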

Compound 3, half-maximal inhibitory concentration: > 100000 nM
Compound 3: a limit, no number; the forecaster's own chance of this, stated with the estimate: 15%; at least 6.6-fold (0.82 log units) between middle value and limit.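

This is the first change shown at this position, and its effect is large: 2-chloroethyl in place of ((chloromethyl)carbonyl)amino on the carbonyl carbon gives an at least 17-fold higher number from compound 2 to compound 3 (1.24 log units; beyond the scatter). The hydroxy step stayed within the scatter, so this position responds far more strongly than the saturated chain carbon did. Compound 3 stands as a limit in this assay, not as a number: the limit of > 100000 nM in this assay, at which 1 of the 3 values shown sits.

Which atoms of the ((chloromethyl)carbonyl)amino group matter stays open. So does how an amine or a longer chain on that carbonyl carbon would behave.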